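Bromo to Chloro in a Pair of Bis-chalcone Phenols

The source may report more compounds than this note shows. Statements on the series, on what has been measured and on what is new or still open speak of the compounds shown alone.

For the measured compounds named here, compound 2 `Cc1cc(O)c(C(=O)/C=C/c2ccccc2)c(-c2ccc(Br)cc2)c1C(=O)/C=C/c1ccccc1` is the only member of this set with a number in an ADME assay on HEK293 cells (Homo sapiens) for cytotoxicity, read by MTT assay, with a stated time of 24 h (a lower number here means a stronger inhibitor, a higher number a weaker inhibitor), where compound 2 gives 30000 nM. Compound 1 `Cc1cc(O)c(C(=O)/C=C/c2ccccc2)c(-c2ccccc2)c1C(=O)/C=C/c1ccccc1` was reported as not active there, giving "not active" (no number reported) without any number attached, and compound 3 `Cc1cc(O)c(C(=O)/C=C/c2ccc(Cl)cc2)c(-c2ccc(OCc3ccccc3)cc2)c1C(=O)/C=C/c1ccc(Cl)cc1` was likewise reported as not active, giving "not active" (no number reported) without any number attached. Compound 4 `Cc1cc(O)c(C(=O)/C=C/c2ccccc2)c(-c2ccc(Cl)cc2)c1C(=O)/C=C/c1ccccc1` differs from compound 2 by chloro in place of bromo on an aromatic carbon. Going by the values given here, no step between two measured compounds is available to calibrate this exchange, so the expectation rests on compound 2 alone. The step of a 1.2-fold higher number from compound 2 to compound 4 (0.07 log units; within the scatter) is expected to be small, not clearly beyond the scatter, and if anything toward a weaker value. Compound 4 is therefore estimated at 35000 nM in this assay, with a range from 15000 nM to 80000 nM.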

Compound 4, half-maximal inhibitory concentration: 5000 nM
Compound 4: the middle estimate sits 7.0-fold (0.85 log units) above what was measured; measured number outside the range, below it.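

Swapping 4-bromophenyl for 4-chlorophenyl gives a 6.0-fold lower number from compound 2 to compound 4 (0.78 log units; beyond the scatter) in this assay. For the compounds shown here, this position, para to a large group, therefore responds measurably to an exchange of one halogen for another, which the earlier compounds could not show. Nothing measured here explains why the chloro compound gives the lower number.

Going by these compounds, the steps from the unsubstituted compound 1 to the two halogen compounds cannot be read, so the effect of adding a halogen at all remains unknown. On these data alone, how fluoro, an amine or a carboxylic acid would read at this position also remains open.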